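The source may report more compounds than this note shows. Statements on the series, on what has been measured and on what is new or still open speak of the compounds shown alone.

Values in an assay on COS-1 cells for displacement of a labelled ligand from sodium-dependent dopamine transporter (Homo sapiens) (on this read-out higher numbers stand for weaker inhibition and lower numbers for stronger inhibition), for the compounds measured so far:
compound 1, `CCN(CC)C(=O)C1=C(c2ccc(Cl)c(Cl)c2)CCC1`: 94000 nM
compound 2, `O=C(OCCF)C1=C(c2ccc(Cl)c(Cl)c2)CCC1`: 500 nM

Compound 2 holds the lower of the two numbers; compound 1 stands apart from it by a 190-fold lower number from compound 1 to compound 2 (2.27 log units; beyond the scatter). Among the compounds with values here, that single step is the only measured comparison, and it concerns an exchange of an amide for an ester on the carbonyl carbon.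

Compound 3, `O=C(Oc1ccccc1)C1=C(c2ccc(Cl)c(Cl)c2)CCC1`, differs from compound 2 by phenyl in place of 2-fluoroethyl on an oxygen next to a carbonyl group. Within the data shown here, no measured step exchanges one ester group for another, so the step recorded, a 190-fold lower number from compound 1 to compound 2 (2.27 log units; beyond the scatter), does not bear directly on this change; it only shows that the carbonyl substituent can move the number a great deal. The ester oxygen is kept, so a step much smaller than that one, in either direction, is expected in this assay. Compound 3 is expected near 1500 nM, within 300 nM to 8000 nM. This estimate amounts to an expected step of a 3.0-fold higher number from compound 2 to compound 3 (0.48 log units; beyond the scatter).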

Compound 3, inhibition constant: 170 nM
Compound 3: the middle estimate sits 8.8-fold (0.95 log units) above what was measured; measured number outside the range, below it.
By their numbers in this assay, from the lowest: compound 3; then compound 2; then compound 1.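

In this assay the group on the ester oxygen itself matters: phenyl in place of 2-fluoroethyl on an oxygen next to a carbonyl group gives a 2.9-fold lower number from compound 2 to compound 3 (0.47 log units; beyond the scatter), so this position accepts an aromatic ring and the number still falls. The second ester also stands far from the diethylamino amide, with phenoxy in place of diethylamino on a carbonyl carbon giving a 550-fold lower number from compound 1 to compound 3 (2.74 log units; beyond the scatter), so the large drop seen earlier is not particular to 2-fluoroethoxy. No evidence on hand accounts for either step.

From the compounds shown here alone, whether the lower number goes with the phenyl ring or with the loss of fluorine stays open, and a plain ethyl ester or a benzyl ester would help separate the two. Substituted phenyl esters and a carboxylic acid on this carbonyl carbon also remain to be placed.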